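The compounds below may be only part of what the source reports. "The series", "measured", "known", "first", "only" and "open" are said of these compounds alone.

Compound 1 `CCN(CC)c1ccc2cc(C(=O)c3ccc(N4CCN(C(=O)CN5CCNCC5)CC4)cc3)oc2c1` gives 320 nM in a functional assay on A549 cells (Homo sapiens) for cytotoxicity, read by MTT assay, with a stated time of 48 h; a lower number here means a stronger inhibitor, a higher number a weaker inhibitor. Compound 2 `C#CCN1CCN(CC(=O)N2CCN(c3ccc(C(=O)c4cc5ccc(N(CC)CC)cc5o4)cc3)CC2)CC1` returns only a limit in this assay, > 40000 nM. That change is an at least 120-fold higher number from compound 1 to compound 2 (2.09 log units; beyond the scatter). Compound 3 `CCN(CC)c1ccc2cc(C(=O)c3ccc(N4CCN(C(=O)CN5CCN(Cc6ccc(F)c(F)c6)CC5)CC4)cc3)oc2c1` gives 5440 nM in this assay, the higher of the two numbers recorded, reached by a 17-fold higher number from compound 1 to compound 3 (1.23 log units; beyond the scatter), while the change from the propargyl compound is an at least 7.3-fold lower number from compound 2 to compound 3 (0.86 log units; beyond the scatter). Compound 4 `CCN(CC)c1ccc2cc(C(=O)c3ccc(N4CCN(C(=O)CN5CCN(Cc6ccc(C(F)(F)F)cc6)CC5)CC4)cc3)oc2c1` differs from compound 3 by 4-(trifluoromethyl)phenyl in place of 3,4-difluorophenyl on a saturated chain carbon bound to an amine nitrogen in a ring. Among the measured compounds shown here, no measured step alters the aromatic ring of the benzyl group itself; the nearest comparison, an at least 7.3-fold lower number from compound 2 to compound 3 (0.86 log units; beyond the scatter), exchanges the whole group on that carbon, and a 17-fold higher number from compound 1 to compound 3 (1.23 log units; beyond the scatter) shows that attaching the benzyl group raises the number. In this assay compound 4 is therefore expected to show a 1.1-fold higher number from compound 3 to compound 4 (0.04 log units; within the scatter), a step within the scatter. The estimate for compound 4 is 6000 nM, between 2000 nM and 20000 nM.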

Compound 4, half-maximal inhibitory concentration: 20100 nM
Compound 4: the middle estimate sits 3.4-fold (0.53 log units) below what was measured, and the stated range ends below it.
By their numbers in this assay, from the lowest: compound 1; then compound 3; then compound 4. At a limit, above all of these: compound 2.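

In this assay, the aromatic ring of the benzyl group itself turns out to matter: a 3.7-fold higher number from compound 3 to compound 4 (0.57 log units; beyond the scatter), so 4-(trifluoromethyl)phenyl and 3,4-difluorophenyl are not interchangeable at this place. Substitution on the ring amine nitrogen again raises the number, now with a 63-fold higher number from compound 1 to compound 4 (1.80 log units; beyond the scatter). The reading an at least 1.9-fold lower number from compound 2 to compound 4 (0.29 log units; that floor lies within the scatter) leaves that pair unordered, since compound 2 stands at a limit: the limit of > 40000 nM in this assay, at which 1 of the 4 values shown sits.

Left open is how an unsubstituted benzyl, or a benzyl ring carrying a methoxy group or a nitrile, would read in this assay. Also open, on these data alone, is whether any group on this nitrogen can match compound 1 at 320 nM.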